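The compounds below may be only part of what the source reports. "The series", "measured", "known", "first", "only" and "open" are said of these compounds alone.

Measured so far in an assay on CHO cells for inhibition of Vasopressin V2 receptor (Homo sapiens), read by radioligand binding; a lower number here means a stronger inhibitor, a higher number a weaker inhibitor:
Compound 1 `CN1CCN(CCCCOc2cc(C(=O)N3CCCCc4sccc43)ccc2NC(=O)c2ccccc2-c2ccccc2)CC1` gives 1 nM.
Compound 3 `CCN(CC)C1CCN(C(=O)CCCOc2cc(C(=O)N3CCCCc4sccc43)ccc2NC(=O)c2ccccc2-c2ccccc2)CC1` gives 9 nM.
Compound 2 `O=C(Nc1ccc(C(=O)N2CCCN(Cc3ccccc3)c3sccc32)cc1)c1ccccc1-c1ccccc1` gives 80 nM.

Among these three, compound 1 has the lowest number, and its gaps to compound 3 and to compound 2 both lie beyond the usual scatter, so it is the strongest inhibitor of the set. Compound 4 `CN1CCCN(CCCOc2cc(C(=O)N3CCCCc4sccc43)ccc2NC(=O)c2ccccc2-c2ccccc2)CC1` has not yet been measured. It holds the same atoms as compound 1, joined differently: 4-methyl-1,4-diazepan-1-yl in place of (4-methylpiperazin-1-yl)methyl on a saturated chain carbon, three bonds along the chain from an oxygen on an aromatic ring. Among the measured compounds shown here, no measured pair isolates this change, so the step can only be judged from the structures. With the atoms merely rearranged, a small step is expected, perhaps a slight loss: a 2.0-fold higher number from compound 1 to compound 4 (0.30 log units; within the scatter). Compound 4 is therefore estimated at 2 nM, within a range from 0.5 nM to 8 nM.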

Compound 4, half-maximal inhibitory concentration: 2 nM
Compound 4: middle estimate and measured number agree at the digits printed; the range from low to high includes it.
By their numbers in this assay, from the lowest: compounds 1 and 4 (each within the scatter of the next); then compound 3; then compound 2.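

Placing 4-methyl-1,4-diazepan-1-yl in place of (4-methylpiperazin-1-yl)methyl on a saturated chain carbon, three bonds along the chain from an oxygen on an aromatic ring, gives a 2.0-fold higher number from compound 1 to compound 4 (0.30 log units; within the scatter). This first readable step shows that, on this core, a seven-membered ring with its shorter chain and a six-membered ring with its longer chain cannot be told apart. No measurement here explains this result. Still open, on these data alone, is whether a morpholine or a simple dimethylamino group would fare as well at the chain end. As far as these compounds go, the effect of chain length alone, with the ring held fixed, also remains unknown.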